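Series notes: removing the aryl substituents of compound 2

The source may report more compounds than this note shows. Statements on the series, on what has been measured and on what is new or still open speak of the compounds shown alone.

Two compounds of the series have numbers in a functional assay on the whole organism (Hindlimb, strain albino) with Mus musculus as the target, in the maximal electroshock model, with a stated time of 0.5 h; a lower number here means that less compound is needed, a higher number that more compound is needed for the effect. Compound 1 `COc1ccc(C2CC(Nc3nc4ccc(C)cc4s3)=NN2C(C)=O)cc1O` gives 73.9 umol/kg. Within the data shown here, compound 2 `COc1ccc(C2CC(Nc3nc4ccc([N+](=O)[O-])cc4s3)=NN2C(C)=O)cc1O` gives 178 umol/kg, the highest of the two numbers; the only measured step, a 2.4-fold higher number from compound 1 to compound 2 (0.38 log units; beyond the scatter), is the nitro in place of methyl on an aromatic carbon and separates compound 2 from its nearest neighbour, compound 1.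

Compound 3 `CC(=O)N1N=C(Nc2nc3ccc([N+](=O)[O-])cc3s2)CC1c1ccccc1` has not yet been measured. It differs from compound 2 as follows: phenyl in place of 3-hydroxy-4-methoxyphenyl on a saturated ring carbon. The change sits on a saturated ring carbon of the five-membered non-aromatic ring and leaves the nitro-bearing part of the shared core untouched. Among the measured compounds shown here, no measured step bears on this change: the single step available, a 2.4-fold higher number from compound 1 to compound 2 (0.38 log units; beyond the scatter), concerns a different place in the molecule, and no measured pair varies the group on the saturated ring carbon. With nothing to point in either direction, the step in this assay is expected to be none beyond the scatter: a 1.0-fold higher number from compound 2 to compound 3 (0.00 log units; within the scatter), with a wide range to reflect the absence of comparable data. Compound 3 is estimated at 180 umol/kg, between 80 umol/kg and 400 umol/kg.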

Compound 3, dose for half-maximal effect: 216 umol/kg
Beside the measured number, compound 3's estimate is 1.2-fold (0.08 log units) below it; low and high end bracket the measured number.
By their numbers in this assay, from the lowest: compound 1; then compounds 2 and 3 (each within the scatter of the next).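

In this assay, among these compounds, phenyl in place of 3-hydroxy-4-methoxyphenyl on a saturated ring carbon gives a 1.2-fold higher number from compound 2 to compound 3 (0.08 log units; within the scatter), the first measured step at this position of the series. With the nitro-bearing part of the shared core held constant, this pair shows that the number stays within the scatter when the aryl group loses both its hydroxy and its methoxy group, so neither group is required for a number of this size on this core. No measurement accompanies this step that could account for it, and the data offer no explanation of the result.

The compounds shown leave open whether the same change would also stay within the scatter on the methyl-bearing core of compound 1, which gives 73.9 umol/kg, and whether the hydroxy and methoxy groups would each read the same alone as they do together. Also open, going by these compounds, is how an amine or a carboxylic acid on the phenyl ring, or a longer chain in place of that ring, would read on this saturated ring carbon.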